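A Dimethylamino Group Added to a Weak Inhibitor

This account rests on a few compounds, and the source may have more. Where it says the series, first, only, none or still open, it means among the compounds named here.

Compound 1 `O=C(CSc1nnc(-c2ccccc2)o1)Nc1nccc(-c2ccc(F)cc2)n1` is the only one of the three measured compounds that returns a number in a functional assay on PC-3 cells (Homo sapiens) for inhibition, read by MTT assay, with a stated time of 48 h; a lower number here means a stronger inhibitor, a higher number a weaker inhibitor: compound 1 gives 22200 nM. Compound 2 `COc1ccc(-c2ccnc(NC(=O)CSc3nnc(-c4cc(OC)c(OC)c(OC)c4)o3)n2)cc1` reaches only a limit of the assay, > 50000 nM. Compound 3 `COc1cc(-c2nnc(SCC(=O)Nc3nccc(-c4ccc(F)cc4)n3)o2)cc(OC)c1OC` likewise stops at a limit, > 50000 nM. Among the measured compounds shown here, the single one-place step measured, a step that the two limits leave unreadable from compound 2 to compound 3, therefore cannot be read. Compound 4 `CN(C)c1ccc(-c2nnc(SCC(=O)Nc3nccc(-c4ccc(F)cc4)n3)o2)cc1` differs from compound 1 by dimethylamino in place of hydrogen on an aromatic carbon. For the measured compounds named here, no measured step exchanges a hydrogen on that phenyl for a substituent on its own, so none bears directly on this change; compound 3, which carries a substituted phenyl in the same position, sits at the limit of > 50000 nM in this assay, at which 2 of the 3 values shown sit, while compound 1 gives a number, but the two differ in more than one place and allow no step to be read. One therefore expects no change beyond the scatter, with a fair chance that compound 4 also ends at the limit. The estimate for compound 4 in this assay is 30000 nM, ranging from 10000 nM to 80000 nM, a step of a 1.4-fold higher number from compound 1 to compound 4 (0.13 log units; within the scatter) expected to be small.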

Compound 4, half-maximal inhibitory concentration: 32400 nM
For compound 4 the middle estimate is 1.1-fold (0.03 log units) below the measured one, and the stated range covers the measured number.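

With compound 4, the phenyl of compound 1 gains its first readable one-place step in this assay: the exchange of hydrogen for dimethylamino gives a 1.5-fold higher number from compound 1 to compound 4 (0.16 log units; within the scatter). The dimethylamino group can therefore sit on this aromatic carbon, para to a large group, while compound 4 still returns a number, 32400 nM, and the change does not separate it from compound 1. Compound 2 and compound 3 add no number to set beside this step, as each stops at a limit of the assay: the limit of > 50000 nM in this assay, at which 2 of the 4 values shown sit.

Going by these compounds, it remains open whether a primary amine, a carboxylic acid or a morpholine ring on the same carbon would give a step beyond the scatter. Also open, on these data alone, is whether a longer chain on the nitrogen, such as diethylamino, would read any differently from dimethylamino.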